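The source may report more compounds than this note shows. Statements on the series, on what has been measured and on what is new or still open speak of the compounds shown alone.

Measured compounds:
- compound 1 `O=c1[nH]cc(S(=O)(=O)Nc2cccc(-c3cn(-c4cccc(F)c4)nn3)c2)c(=O)[nH]1`: 7200 nM
- compound 2 `Cc1ccccc1-n1cc(-c2ccc(NS(=O)(=O)c3c[nH]c(=O)[nH]c3=O)cc2)nn1`: 3130 nM

In a functional assay on A549 cells (Homo sapiens) for antiproliferative activity, read by MTT assay, with a stated time of 24 h (a lower number here means a stronger inhibitor, a higher number a weaker inhibitor), compound 2 gives 3130 nM, the lowest of the two numbers measured. The nearest is compound 1, which in this assay gives 7200 nM; that gap lies beyond the usual scatter, and since the two compounds differ in more than one place, the numbers alone are all that can be said of them.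

Compound 3 `O=c1[nH]cc(S(=O)(=O)Nc2ccc(-c3cn(-c4ccccc4F)nn3)cc2)c(=O)[nH]1` has not yet been measured. Its difference from compound 2 is fluoro in place of methyl on an aromatic carbon, a fluoro in place of methyl on an aromatic carbon. No comparable single change has been measured here, so the step from compound 2 to compound 3 in this assay is expected to be small, in either direction, most likely not beyond the scatter, which is what a 1.1-fold higher number from compound 2 to compound 3 (0.05 log units; within the scatter) expresses. Compound 3 is therefore estimated at 3500 nM, within a range of 1500 nM to 8500 nM.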

Compound 3, half-maximal inhibitory concentration: 5960 nM
The estimate for compound 3 lay 1.7-fold (0.23 log units) below the measured number; measured number inside the range.
By their numbers in this assay, from the lowest: compounds 2, 3 and 1 (each within the scatter of the next, the first and the last beyond it).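

In this assay, exchanging methyl for fluoro on an aromatic carbon ortho to a large group gives a 1.9-fold higher number from compound 2 to compound 3 (0.28 log units; within the scatter), the first single change measured at this position. The 2-methylphenyl and 2-fluorophenyl compounds therefore cannot be told apart by this read-out, something the earlier pair, differing in more than one place, could not show. Nothing measured here gives a reason for this result.

Going by these compounds, it remains open whether any group at this position would separate from these two beyond the scatter, for instance an amine, a methoxy group or a carboxylic acid. Also open, on these data alone, is whether the plain phenyl compound, with only hydrogen there, would give a number in the same range as compound 2 and compound 3.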